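A few compounds are considered here, and "the series" means these few. Any claim that something is new, unique, unknown or untested is made for them only; others in the source may bear on it.

Compound 1 `CCN(CC)C(=O)[C@@H]1CN[C@H](C(=O)N2CCC[C@H]2C#N)C1` is the starting point of this step, and in an assay on the whole organism (plasma, strain Sprague-Dawley) for inhibition of Dipeptidyl peptidase 4 (Rattus norvegicus), with a stated time of 10 h, at a dose of 1 mg/kg by the oral route (on this read-out higher numbers stand for more inhibition at the one dose given (going by the name of the read-out) and lower numbers for less inhibition), compound 1 gave "not determined" (no result reported), so compound 1 stands nowhere on the measured scale. Two related compounds do carry results. Compound 2 `C[C@@H]1N[C@H](C(=O)N2CCC[C@H]2C#N)C[C@@H]1C(=O)N1CCOCC1` gives 85% in this assay, and compound 3 `C[C@@H]1N[C@H](C(=O)N2CCC[C@H]2C#N)C[C@@H]1C(=O)N1CCCC1` gives 88%. The difference between them is pyrrolidin-1-yl in place of morpholin-4-yl on a carbonyl carbon, and the measured step was a number 3 percentage points higher from compound 2 to compound 3 (within the scatter).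

The step under study leads to compound 4 `CN(C)C(=O)[C@@H]1CN[C@H](C(=O)N2CCC[C@H]2C#N)C1`. It differs from compound 1 as follows: dimethylamino in place of diethylamino on a carbonyl carbon. Among the measured compounds shown here, no measured pair exchanges one amine for another on that carbonyl carbon in the same way, and the only measured exchange of a group on a carbonyl carbon stayed within the scatter, so there is no basis for expecting a direction beyond the scatter. What the data do show is that compound 2 and compound 3, which share the nitrile-bearing amide with compound 4, both reach high inhibition in this assay.

Compound 4 is therefore expected to give about 75% in this assay, with the estimate ranging from 45% to 95%.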

Compound 4, a percentage reported as inhibition, in the whole organism at one dose (the size of the read-out at that dose, not a potency): 52%
Beside the measured number, compound 4's estimate is 23 percentage points above it; measured number inside the range.
By their numbers in this assay, from the lowest: compound 4; then compounds 2 and 3 (each within the scatter of the next).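

In this assay compound 1 gives "not determined" (no result reported), so the step from compound 1 to compound 4 cannot be read. Nothing shown here bears on the result for compound 4. As far as these compounds go, whether dimethylamino in place of diethylamino raises or lowers inhibition on this core remains open.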